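Pyrrolidone-core thiazolidinones: swap of the exocyclic aryl group

The source may hold more compounds than are shown below. What is called first, only, known or untested is meant among the compounds shown, and "the series" means these compounds.

Measured so far:
compound 1 `CCOC(=O)C1=C(Nc2ccccc2)S/C(=C\c2cccc(C(=O)O)c2)C1=O` — 50.6%
compound 2 `CCOC(=O)C1=C(Nc2cccc(C(F)(F)F)c2)S/C(=C\c2ccc[nH]2)C1=O` — 52.9%

In a functional assay on JAR cells (Homo sapiens) for inhibition, read by MTT assay, with a stated time of 72 h, tested at 10 uM (a lower number here means less inhibition, a higher number more inhibition at the concentration tested (going by the name of the read-out)), compound 1 gives 50.6%. In this assay compound 2 gives 52.9%; the gap between compound 1 and compound 2 is within the scatter, so compound 1 stands at the smaller of two numbers that cannot be told apart. Going by the values given here, no step between measured compounds is available.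

Compound 3 `CCOC(=O)C1=C(Nc2ccccc2)S/C(=C\c2cc3ncccc3[nH]2)C1=O` is unmeasured. It differs from compound 1 as follows: a group of 9 heavy atoms (7 carbon, 2 nitrogen; one five-membered aromatic ring with 1 hetero atom, one six-membered aromatic ring with 1 hetero atom) in place of a group of 9 heavy atoms (7 carbon, 2 oxygen; one six-membered aromatic ring of carbon only), on a double-bonded chain carbon bound to a double-bonded ring carbon. Among the compounds with values here, with no comparable step in hand, the expected step in this assay is none beyond the scatter, and the step expected is a number 0.6 percentage points lower from compound 1 to compound 3 (within the scatter). For compound 3 the estimate in this assay is 50%, ranging from 30% to 70%.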

Compound 3, a percentage reported as inhibition, at one concentration (the size of the read-out at that concentration, not a potency): 74.8%
For compound 3 the middle estimate is 24.8 percentage points below the measured one; the whole stated range lies below it.
By their numbers in this assay, from the lowest: compounds 1 and 2 (each within the scatter of the next); then compound 3.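

In this assay, the first step readable at this position, on a double-bonded chain carbon bound to a double-bonded ring carbon, is a number 24.2 percentage points higher from compound 1 to compound 3 (beyond the scatter). Replacing 3-carboxyphenyl with a group of one five-membered and one six-membered aromatic ring, each with 1 hetero atom, therefore moves the read-out at this position, although both groups have 9 heavy atoms. No measurement in hand explains this step.

Still open, from the compounds shown here alone, is whether the step follows the loss of the carboxylic acid or the arrival of the two rings. A plain phenyl or a methyl ester at this place would separate the two.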